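The source may hold more compounds than are shown below. What is called first, only, known or untested is meant among the compounds shown, and "the series" means these compounds.

Working notes on the series. Compound 3 `CCn1c(=O)n(C2OC(CO)[C@@H](O)[C@H]2O)c2nc(N)nc(O)c21` gives 82% in a functional assay on the whole organism (B cells) with Mus musculus as the target (a higher number here means a larger maximal response, a lower number a smaller maximal response), the second highest of the three numbers in hand. Its nearest neighbour is compound 2 `CCOC(=O)Cn1c(=O)n(C2OC(CO)[C@@H](O)[C@H]2O)c2nc(N)nc(O)c21` with 86%, and the step of a number 4 percentage points lower from compound 2 to compound 3 (within the scatter) lies within the scatter. Furthest off is compound 1 `Nc1nc(O)c2c(n1)n(C1OC(CO)[C@@H](O)[C@H]1O)c(=O)n2C/C=C/c1ccccc1` with 73%; the step of a number 9 percentage points higher from compound 1 to compound 3 (within the scatter) also lies within the scatter, whereas a number 13 percentage points higher from compound 1 to compound 2 (beyond the scatter) is the one step beyond it.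

The next compound is compound 4 `Nc1nc(O)c2c(n1)n(C1OC(CO)[C@@H](O)[C@H]1O)c(=O)n2Cc1ccc([N+](=O)[O-])cc1`. The change from compound 3 is 4-nitrophenyl in place of methyl on a saturated chain carbon bound to an aromatic nitrogen.

Among the compounds with values here, no measured step covers this change directly. Within the data shown here, the steps that bear on it are those at the same place: a number 9 percentage points higher from compound 1 to compound 3 (within the scatter), where a group carrying a phenyl ring gave way to methyl without a step beyond the scatter, and a number 13 percentage points higher from compound 1 to compound 2 (beyond the scatter), a modest step. Among the measured compounds shown here, the three measured values span a narrow band, so the expected step of a number 5 percentage points lower from compound 3 to compound 4 (within the scatter) is none beyond the scatter, leaning slightly downward because compound 1, the one measured compound carrying a phenyl ring at this place, gives 73%. For compound 4 the estimate in this assay is 77%, with a range from 62% to 90%.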

Compound 4, largest response reached (reported as maximal response), in percent of the reference or control that the assay uses: 147%
For compound 4 the middle estimate is 70 percentage points below the measured one; measured number above the stated range.
By their numbers in this assay, from the lowest: compounds 1, 3 and 2 (each within the scatter of the next, the first and the last beyond it); then compound 4.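

Within the data shown here, at this place, on a saturated chain carbon bound to an aromatic nitrogen, the choice of group can shift the maximal response in this assay far more than the earlier compounds suggested, with a number 65 percentage points higher from compound 3 to compound 4 (beyond the scatter) and a number 61 percentage points higher from compound 2 to compound 4 (beyond the scatter) as well as a number 74 percentage points higher from compound 1 to compound 4 (beyond the scatter), all large steps, where the first three compounds offered only one modest step. A phenyl ring in the group does not on its own give this result: compound 1 carries one in its 2-phenylethenyl group and still lies far under compound 4, so the difference is tied to the 4-nitrophenyl group as a whole rather than to the presence of an aromatic ring. Nothing at hand explains why this group stands so far apart from the other three.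

Still open, going by these compounds, is how much of the step belongs to the nitro group and how much to the ring attached directly to the chain carbon. A plain phenyl, a 4-aminophenyl or a 4-methoxyphenyl group at this place would separate the two, and would show whether compound 4 is a single outlier or part of a trend.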